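A few compounds are considered here, and "the series" means these few. Any claim that something is new, unique, unknown or untested is made for them only; others in the source may bear on it.

Working notes on the series. The shared core is an amide-linked proline unit carrying a sulfonamide-bearing piperidine; the variable part is the acyl group on the proline nitrogen. Compound 1 `CC(C)C(=O)N1CCC[C@H]1C(=O)N1CCC(NS(=O)(=O)c2cc(S(=O)(=O)c3ccccc3)ccc2C(F)(F)F)CC1` gives 40 nM in an assay on isolated protein for binding affinity to secreted frizzled-related protein 1 (Homo sapiens), read by fluorescence; a higher number here means a weaker inhibitor, a lower number a stronger inhibitor. Compound 2 `CN(C)C(=O)N1CCC[C@H]1C(=O)N1CCC(NS(=O)(=O)c2cc(S(=O)(=O)c3ccccc3)ccc2C(F)(F)F)CC1` gives 30 nM in this assay. Of the two numbers recorded, compound 2 carries the lower one, but the step of a 1.3-fold lower number from compound 1 to compound 2 (0.12 log units; within the scatter) lies within the scatter, so the two compounds are not separated.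

Compound 3 `O=C([C@@H]1CCCN1C(=O)N1CCOCC1)N1CCC(NS(=O)(=O)c2cc(S(=O)(=O)c3ccccc3)ccc2C(F)(F)F)CC1` differs from compound 2 by morpholin-4-yl in place of dimethylamino on a carbonyl carbon. For the measured compounds named here, the only measured step that bears on this change is the one at the same carbonyl carbon, a 1.3-fold lower number from compound 1 to compound 2 (0.12 log units; within the scatter), which stayed within the scatter. On that basis no step beyond the scatter is expected for compound 3, a 1.3-fold higher number from compound 2 to compound 3 (0.12 log units; within the scatter). The estimate for compound 3 in this assay is 40 nM, with a range from 15 nM to 110 nM.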

Compound 3, half-maximal inhibitory concentration in the secreted frizzled-related protein 1 assay: 40 nM
Compound 3: middle estimate and measured number agree at the digits printed, and the stated range covers the measured number.
By their numbers in the secreted frizzled-related protein 1 assay, from the lowest: compounds 2, 1 and 3 (each within the scatter of the next).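

In the secreted frizzled-related protein 1 assay the place on the carbonyl carbon now holds a ring, compound 3 gives 40 nM, and the results are a 1.3-fold higher number from compound 2 to compound 3 (0.12 log units; within the scatter) and no change at the digits printed from compound 1 to compound 3 (within the scatter), so isopropyl, dimethylamino and morpholin-4-yl are not separated here. Going to morpholin-4-yl brings 6 heavy atoms in place of 3, one six-membered non-aromatic ring and 1 hydrogen-bond acceptor, and none of this gives a step beyond the scatter. In a physicochemical assay for solubility (on this read-out lower numbers stand for lower solubility and higher numbers for higher solubility), compound 2 gives 100000 nM and compound 3 gives 50000 nM, and the same change gives a 2.0-fold lower number from compound 2 to compound 3 (0.30 log units; within the scatter), so compound 2 and compound 3 are not separated on this read-out either.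

As far as these compounds go, whether a primary amine, a carboxylic acid or a longer chain at this carbonyl carbon would move the number in the secreted frizzled-related protein 1 assay beyond the scatter stays open. No measurement at hand explains why these three groups are not separated.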